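Working notes: group exchange on the aromatic-ring nitrogen

This account rests on a few compounds, and the source may have more. Where it says the series, first, only, none or still open, it means among the compounds named here.

Measured so far in a functional assay on K562 cells (Homo sapiens) for inhibition, read by trypan blue exclusion, with a stated time of 72 h; a higher number here means a weaker inhibitor, a lower number a stronger inhibitor:
- compound 1 `Cn1c(=O)c(S(=O)(=O)c2ccc(F)cc2F)cc2cnc(Nc3ccc4[nH]c(C(=O)O)cc4c3)nc21` gives 10000 nM
- compound 2 `Cn1c(=O)c(S(=O)(=O)c2ccc(F)cc2F)cc2cnc(Nc3ccc4c(c3)CC(=O)N4)nc21` gives 15000 nM

With only these two values, compound 2 cannot be ranked apart from compound 1. For the measured compounds named here, the single measured step is a 1.5-fold higher number from compound 1 to compound 2 (0.18 log units; within the scatter) and it lies within the scatter.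

The next compound is compound 3 `Cn1c(=O)c(S(=O)(=O)c2ccc(F)cc2F)cc2cnc(Nc3ccc4cccc(O)c4n3)nc21`, which is still to be measured in this assay and differs from compound 2 as follows: a group of 11 heavy atoms (9 carbon, 1 nitrogen, 1 oxygen; one six-membered aromatic ring of carbon only, one six-membered aromatic ring with 1 hetero atom) in place of a group of 10 heavy atoms (8 carbon, 1 nitrogen, 1 oxygen; one five-membered non-aromatic ring with 1 hetero atom, one six-membered aromatic ring of carbon only), on a nitrogen on an aromatic ring

Going by the values given here, the one measured step bears on this change, since it also exchanged the group on a nitrogen on an aromatic ring while the rest of the structure stayed the same. That exchange left the two values within the scatter of each other. Among the compounds with values here, one step is thin evidence, and no measured compound carries the 8-hydroxyquinolin-2-yl group, so the range has to stay wide. No step beyond the scatter is expected, in either direction.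

The estimated step is a 1.5-fold lower number from compound 2 to compound 3 (0.18 log units; within the scatter) and it stays within that expectation.

For compound 3 the expected value is 10000 nM with an estimated range from 2500 nM to 30000 nM in this read-out.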

Compound 3, half-maximal inhibitory concentration: 5000 nM
For compound 3 the middle estimate is 2.0-fold (0.30 log units) above the measured one; low and high end bracket the measured number.
By their numbers in this assay, from the lowest: compounds 3, 1 and 2 (each within the scatter of the next, the first and the last beyond it).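

In this assay, the exchange on a nitrogen on an aromatic ring now gives its first step beyond the scatter: with 8-hydroxyquinolin-2-yl entering, the change is a 3.0-fold lower number from compound 2 to compound 3 (0.48 log units; beyond the scatter) and is modest in size. The same entering group, set against 2-carboxy-1H-indol-5-yl, gives a 2.0-fold lower number from compound 1 to compound 3 (0.30 log units; within the scatter) and stays within the scatter, so 8-hydroxyquinolin-2-yl is separated from the group of compound 2 but not from the group of compound 1, and compound 3 cannot be ranked apart from compound 1. For the compounds shown here, this position therefore tolerates three quite different groups with only a small spread in the read-out, and nothing measured so far accounts for the one step that exceeds the scatter.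

The compounds shown leave open whether the step from the group of compound 2 goes with the hydroxyl or with the two-ring quinoline itself, and a plain quinolin-2-yl or an 8-aminoquinolin-2-yl group on the same nitrogen would separate the two. Also open, from the compounds shown here alone, is whether any group at this place, such as a simple phenyl or a longer chain ending in an amine, moves the number further than these three do on the shared core.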